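A few compounds are considered here, and "the series" means these few. Any claim that something is new, unique, unknown or untested is made for them only; others in the source may bear on it.

Measured compounds:
- compound 1 `CN(C)c1ccc(C2CC(c3ccccc3)=NN2C2=NC(=O)/C(=C3\C(=O)Nc4ccc(Br)cc43)S2)cc1`: 540 nM
- compound 2 `CN(C)c1ccc(C2CC(c3ccccc3)=NN2C2=NC(=O)/C(=C3\C(=O)Nc4ccc(Cl)cc43)S2)cc1`: 510 nM
- compound 3 `COc1ccc(-c2cc(-c3ccc(Cl)cc3)n(C3C(=O)Nc4ccc(Br)cc43)n2)cc1`: 30000 nM

All three numbers come from a functional assay on cells (Cancer cell lines, Homo sapiens) for cytotoxicity, read by sulforhodamine B assay, with a stated time of 48 h; on this read-out lower numbers stand for stronger inhibition of growth and higher numbers for weaker inhibition of growth. Compound 1 and compound 2 share one core and differ only in the change (chloro in place of bromo on an aromatic carbon). That step is a 1.1-fold lower number from compound 1 to compound 2 (0.02 log units; within the scatter), so the two numbers are indistinguishable on this read-out.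

Compound 3 is built on a different core. The difference between the core of compound 1 and the core of compound 3 is not broken down here; what the values show is that in this assay compound 3 gives 30000 nM, a far higher number than either of the other two, beyond the scatter in both comparisons.

Compound 4 `COc1ccc(-c2cc(-c3ccc(Cl)cc3)n(C3C(=O)Nc4ccc(Cl)cc43)n2)cc1` is not yet measured. It differs from compound 3 by chloro in place of bromo on an aromatic carbon, which is the same change that was made from compound 1 to compound 2, at a place described in identical words. Among the compounds shown, this change occurs twice in all, once measured and once pending. Within the data shown here, the only precedent for it is the measured step of a 1.1-fold lower number from compound 1 to compound 2 (0.02 log units; within the scatter), which lies within the scatter. Among the measured compounds shown here, on that basis the step from compound 3 to compound 4 is expected to be a 1.0-fold lower number from compound 3 to compound 4 (0.01 log units; within the scatter), also within the scatter, because the one observed instance of this change, a 1.1-fold lower number from compound 1 to compound 2 (0.02 log units; within the scatter), moved the number hardly at all. Compound 4 is therefore estimated at 29000 nM in this assay, with a plausible range of 12000 nM to 70000 nM. This expectation rests on a single precedent on a different core and should be treated with caution.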

Compound 4, concentration for total growth inhibition: 23200 nM
For compound 4 the middle estimate is 1.3-fold (0.10 log units) above the measured one; measured number inside the range.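

In this assay, chloro in place of bromo on the aromatic carbon gives a 1.3-fold lower number from compound 3 to compound 4 (0.11 log units; within the scatter), so on this second core the change again cannot be told apart from repeated measurement. Set beside the earlier step, the two cores give the same picture for this change: the same change on two cores in this assay, a 1.1-fold lower number (0.02 log units; within the scatter) from compound 1 to compound 2 and a 1.3-fold lower number (0.11 log units; within the scatter) from compound 3 to compound 4, 1.2-fold (0.09 log units) apart, within the scatter of two such steps

This supports treating the exchange of bromo for chloro as carrying over between these two cores in this read-out, but two cores are a narrow base, and a step this small shows neither that larger changes would carry over nor why this one has so little effect.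

Whether a fluoro, a nitrile or a carboxylic acid on that same aromatic carbon, or a hydrogen there, would shift the number beyond the scatter remains open, since the compounds shown hold only bromo and chloro at that place. Each core also appears with a single set of other groups, so it cannot be told whether the exchange would stay this small if those groups were altered.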